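The compounds below may be only part of what the source reports. "The series", "measured", "known", "first", "only" and "open" are said of these compounds alone.

Measured so far:
- compound 1, `COc1ccc2nc(C)cc(NC(=O)C(=O)Nc3cc(C)cc(C)c3)c2c1`: 6.47
- compound 2, `COc1ccc2nc(C)cc(OCC(=O)NCc3cc(C)cc(C)c3)c2c1`: 5.25

In a physicochemical assay for lipophilicity, read by HPLC, in phosphate buffer, measured as chromatographic lipophilicity, at pH 7.4 (a higher number here means a more lipophilic compound, a lower number a more polar compound), compound 1 gives 6.47. Compound 2 holds the lower of the two numbers; in this assay compound 2 gives 5.25, and compound 1 sits a step above it that goes beyond the scatter. Compound 3, `COc1ccc2nc(C)cc(OCC(=O)Nc3c(C)cncc3C)c2c1`, has not yet been measured. It differs from compound 2 in one place: 3,5-dimethylpyridin-4-yl in place of 3,5-dimethylbenzyl on an amide-type nitrogen. Within the data shown here, no measured pair shows this change, so its size is open. For compound 3 a step downward beyond the scatter is expected, a number 1.45 log units lower from compound 2 to compound 3 (beyond the scatter), giving an estimated 3.8 with a range from 3.1 to 4.5.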

Compound 3, distribution coefficient: 3.01
The estimate for compound 3 lay 0.79 log units above the measured number, outside the stated range (below it).
By their numbers in this assay, from the lowest: compound 3; then compound 2; then compound 1.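

In this assay, the group on this amide-type nitrogen can move the number a long way: 3,5-dimethylpyridin-4-yl in place of 3,5-dimethylbenzyl gives a number 2.24 log units lower from compound 2 to compound 3 (beyond the scatter). The entering group has one hydrogen-bond acceptor and the leaving group none, and the two also differ in heavy atoms. Nothing measured here explains the step.

Among these compounds, the single swap changes both the ring and the atom count, so their shares remain unknown. A 3,5-dimethylphenyl group at this place would help separate them.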